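This account rests on a few compounds, and the source may have more. Where it says the series, first, only, none or still open, it means among the compounds named here.

In a functional assay on SK-MEL-28 cells (Homo sapiens) for cytotoxicity, read by CCK-8 assay, with a stated time of 24 h (a higher number here means a weaker inhibitor, a lower number a stronger inhibitor), three compounds have been measured so far:

- compound 1 `COc1ccccc1Oc1c(N)nc(-c2cccc(C)c2)nc1Cl` gives 54000 nM
- compound 2 `COc1ccccc1Oc1c(N)nc(-c2ccc(Br)cc2)nc1Cl` gives 14 nM
- compound 3 `COc1ccccc1Oc1c(N)nc(-c2cccc(C)c2)nc1OCCO` gives 14700 nM

Compound 3 holds the middle place among these three numbers. It lies far above compound 2 and much nearer to compound 1, and the modest step between those neighbours is a 3.7-fold lower number from compound 1 to compound 3 (0.57 log units; beyond the scatter).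

Compound 4 `COc1ccccc1Oc1c(N)nc(-c2cccc(I)c2)nc1OCCO` has not yet been measured. It differs from compound 3 in one place: iodo in place of methyl on an aromatic carbon.

Within the data shown here, no measured pair makes exactly this change. The closest evidence is the large step of a 3900-fold lower number from compound 1 to compound 2 (3.59 log units; beyond the scatter), where 4-bromophenyl replaces 3-methylphenyl. That step shows how far a change in this group can move the number in this assay. It is only a loose guide, though, since 4-bromophenyl is not 3-iodophenyl, and compound 2 carries chloro where compound 3 carries 2-hydroxyethoxy.

A lower number is therefore expected, but only part of that large step, and with wide uncertainty. The expected change is a 9.8-fold lower number from compound 3 to compound 4 (0.99 log units; beyond the scatter). The estimate for compound 4 is 1500 nM, with an expected range of 60 nM to 15000 nM.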

Compound 4, half-maximal inhibitory concentration: 11200 nM
Compound 4: the middle estimate sits 7.5-fold (0.87 log units) below what was measured; the range from low to high includes it.
By their numbers in this assay, from the lowest: compound 2; then compounds 4 and 3 (each within the scatter of the next); then compound 1.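

In this assay, replacing methyl with iodo on an aromatic carbon, meta to a large group, gives a 1.3-fold lower number from compound 3 to compound 4 (0.12 log units; within the scatter), so this swap has no readable effect on the number when 2-hydroxyethoxy is present. The 3-methylphenyl and 3-iodophenyl compounds therefore cannot be told apart here, and placing a single iodine at this position is not enough to reach anything like the low number of compound 2, which carries 4-bromophenyl and chloro. No measurement among the data shown explains why this change leaves the number within the scatter.

The compounds shown leave open whether the large step of a 3900-fold lower number from compound 1 to compound 2 (3.59 log units; beyond the scatter) depends on the ring position of the halogen, on bromo as opposed to iodo, or on the chloro that compound 2 keeps in place of 2-hydroxyethoxy. Going by these compounds, a 4-bromophenyl group paired with 2-hydroxyethoxy, or a 3-bromophenyl or 4-iodophenyl group paired with chloro, would help separate these possibilities, and an amine or a carboxylic acid at this ring position remains unexplored here.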